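Swapping the pyridyl ether for a fluorophenyl ether

This account rests on a few compounds, and the source may have more. Where it says the series, first, only, none or still open, it means among the compounds named here.

Compound 1 `Cc1cccc(OC(c2ccc(Br)cc2)C2CCN(C(C)CCNC(=O)c3c(Cl)cncc3Cl)CC2)n1`: 6500 nM
Compound 2 `Cc1cccnc1OC(c1ccc(C(F)(F)F)cc1)C1CCN(C(C)CCNC(=O)c2c(Cl)cncc2Cl)CC1`: 33000 nM
Compound 3 `CC(CCNC(=O)c1c(Cl)cncc1Cl)N1CCC(C(O)c2ccc(Br)cc2)CC1`: 198000 nM

In an ADME assay on PBMC cells (Homo sapiens) for cytotoxicity (on this read-out higher numbers stand for lower toxicity in this test and lower numbers for higher toxicity in this test), compound 2 gives 33000 nM, the second highest of the three numbers, above compound 1 and well below compound 3. Compound 4 `CC(CCNC(=O)c1c(Cl)cncc1Cl)N1CCC(C(Oc2cccc(F)c2)c2ccc(C(F)(F)F)cc2)CC1` differs from compound 2 in one place: 3-fluorophenyl in place of 3-methylpyridin-2-yl on an oxygen on a saturated carbon. Going by the values given here, the only measured step, a 30-fold higher number from compound 1 to compound 3 (1.48 log units; beyond the scatter), removes the aryl group from that oxygen entirely, whereas here one aryl ether is exchanged for another, so that step bears on this change only loosely. Among the compounds with values here, with no closer precedent, the expected step of a 1.3-fold lower number from compound 2 to compound 4 (0.12 log units; within the scatter) is none beyond the scatter. Compound 4 is therefore estimated at 25000 nM in this assay, with a range from 8000 nM to 80000 nM.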

Compound 4, half-maximal cytotoxic concentration: 5400 nM
Estimate against measurement, compound 4: 4.6-fold (0.67 log units) above, outside the stated range (below it).
By their numbers in this assay, from the lowest: compounds 4 and 1 (each within the scatter of the next); then compound 2; then compound 3.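

Exchanging one aryl group for another on this oxygen is not a neutral change in this assay: 3-fluorophenyl in place of 3-methylpyridin-2-yl gives a 6.1-fold lower number from compound 2 to compound 4 (0.79 log units; beyond the scatter). The identity of the aryl group therefore moves the number, whereas a 30-fold higher number from compound 1 to compound 3 (1.48 log units; beyond the scatter) showed only what removing it does. Nothing measured here accounts for this step. The compounds shown do not separate the loss of the ring nitrogen and methyl from the gain of fluorine. As far as these compounds go, how an unsubstituted phenyl on this oxygen would read also remains open.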